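The compounds below may be only part of what the source reports. "The series", "measured", "known", "first", "only" and "open" are said of these compounds alone.

Measured so far:
compound 1 `Cc1cccc(-c2nc(CNc3ccc(C(=O)NO)cc3)n(-c3ccccc3)n2)c1` — 64.1%
compound 2 `O=C(NO)c1ccc(NCc2nc(-c3ccccc3)nn2-c2ccc(C(F)(F)F)cc2)cc1` — 38.9%

In an assay on Sf9 cells for inhibition of protein deacetylase HDAC6 (Homo sapiens), read by fluorescence, with a stated time of 40 min, tested at 100 nM (on this read-out lower numbers stand for less inhibition and higher numbers for more inhibition at the one concentration tested (going by the name of the read-out)), compound 1 gives 64.1%, the higher of the two numbers; compound 2 gives 38.9%, a gap beyond the usual scatter. Compound 3 `O=C(NO)c1ccc(NCc2nc(-c3ccsc3)nn2-c2ccccc2)cc1` is not yet measured. It differs from compound 1 in one place: thiophen-3-yl in place of 3-methylphenyl on an aromatic carbon. Among the compounds with values here, no measured pair isolates a change of this kind, so its size is not known from the data. The expected step is a number 9.1 percentage points lower from compound 1 to compound 3 (within the scatter), a small loss at most, near the edge of the scatter. In this assay compound 3 is estimated at 55%, within a range from 35% to 75%.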

Compound 3, a percentage reported as inhibition, at one concentration (the size of the read-out at that concentration, not a potency): 53.4%
Estimate against measurement, compound 3: 1.6 percentage points above; the measured number falls inside the stated range.
By their numbers in this assay, from the lowest: compound 2; then compound 3; then compound 1.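

In this assay, thiophen-3-yl in place of 3-methylphenyl on the aromatic carbon between two ring nitrogen atoms gives a number 10.7 percentage points lower from compound 1 to compound 3 (beyond the scatter), the first measured size for a change at this position. Compound 3 shows that a five-membered aromatic ring with one sulfur is accepted here with a modest loss and that inhibition remains measurable at the tested concentration. Nothing available gives a reason for this step.

The compounds shown do not separate the effect of the methyl group from that of the ring itself. From the compounds shown here alone, how a pyridin-3-yl or a thiophen-2-yl group would read at this position remains open.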